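A few compounds are considered here, and "the series" means these few. Any claim that something is new, unique, unknown or untested is made for them only; others in the source may bear on it.

In an assay on HEK293 cells for inhibition of Voltage-dependent T-type calcium channel subunit alpha-1G (Homo sapiens), read by fluorescence, tested at 10 uM (a lower number here means less inhibition, a higher number more inhibition at the concentration tested (going by the name of the read-out)), compound 3 `CCCc1nc(-c2ccccc2)c(CNCCCN2CCN(c3ccccc3)CC2)o1` gives 43.7%, the lowest of the three numbers in hand, though its gap to compound 1 stays within the scatter. Compound 1 `CCCc1nc(-c2ccccc2)c(CNCCCN2CCN(c3ccccc3C(F)(F)F)CC2)o1` gives 45%, and compound 2 `CCCc1nc(-c2ccccc2)c(CNCCCN2CCN(c3cccc(C)c3C)CC2)o1` gives 55.2%. The step of a number 1.3 percentage points lower from compound 1 to compound 3 (within the scatter) is within the scatter, whereas a number 11.5 percentage points lower from compound 2 to compound 3 (beyond the scatter) and a number 10.2 percentage points higher from compound 1 to compound 2 (beyond the scatter) are modest and beyond it. Compound 4 `CCCc1nc(-c2ccccc2)c(CNCCCN2CCN(c3ccc(C)cc3)CC2)o1` carries methyl in place of hydrogen on an aromatic carbon. Only the 2,3-dimethylphenyl-to-phenyl change concerns methyl groups on this ring, and it moved the number modestly; a single methyl is therefore expected to give no more than a small rise, probably inside the scatter. Compound 4 is expected to give 50%, between 38% and 62%. This estimate means an expected step of a number 6.3 percentage points higher from compound 3 to compound 4 (within the scatter).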

Compound 4, a percentage reported as inhibition, at one concentration (the size of the read-out at that concentration, not a potency): 53.9%
Estimate against measurement, compound 4: 3.9 percentage points below; measured number inside the range.
By their numbers in this assay, from the lowest: compounds 3, 1, 4 and 2 (each within the scatter of the next, the first and the last beyond it).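

In this assay, a single methyl on the aromatic carbon para to a large group is enough for a number 10.2 percentage points higher from compound 3 to compound 4 (beyond the scatter), so one methyl at this place, without a second on the ring, already moves the number. With a number 1.3 percentage points lower from compound 2 to compound 4 (within the scatter) and a number 8.9 percentage points higher from compound 1 to compound 4 (within the scatter), 4-methylphenyl cannot be separated from either 2,3-dimethylphenyl or 2-(trifluoromethyl)phenyl in this read-out. No measurement in hand explains the step from hydrogen to methyl. From the compounds shown here alone, whether ethyl, methoxy or chlorine in place of this methyl gives a similar number remains open.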